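Ether or ester on the shared core: compound 3 to compound 4

The source may report more compounds than this note shows. Statements on the series, on what has been measured and on what is new or still open speak of the compounds shown alone.

In a functional assay on HeLa cells (Homo sapiens) for cytotoxicity, read by MTT assay (on this read-out lower numbers stand for stronger inhibition and higher numbers for weaker inhibition), compound 1 (`CC(C)=CC[C@@H](OC[C@H](C)O)C1=CC(=O)c2c(O)ccc(O)c2C1=O`) gives 40300 nM, compound 2 (`CC(C)=CC[C@@H](OC(=O)c1ccco1)C1=CC(=O)c2c(O)ccc(O)c2C1=O`) gives 80300 nM and compound 3 (`CCCCC(O)CC(=O)O[C@H](CC=C(C)C)C1=CC(=O)c2c(O)ccc(O)c2C1=O`) gives 72200 nM. Compound 3 lies within the scatter of both others, as shown by a 1.1-fold lower number from compound 2 to compound 3 (0.05 log units; within the scatter) and a 1.8-fold higher number from compound 1 to compound 3 (0.25 log units; within the scatter).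

The next structure is compound 4 (`CC(=O)OCCO[C@H](CC=C(C)C)C1=CC(=O)c2c(O)ccc(O)c2C1=O`), and the change is 2-acetoxyethyl in place of (2-hydroxyhexyl)carbonyl on an oxygen on a saturated carbon. In words, 2-acetoxyethyl stands in place of (2-hydroxyhexyl)carbonyl on an oxygen on a saturated carbon. For the measured compounds named here, no measured compound carries 2-acetoxyethyl. The nearest evidence is the set of changes on that same oxygen, namely a 1.8-fold higher number from compound 1 to compound 3 (0.25 log units; within the scatter) and a 2.0-fold higher number from compound 1 to compound 2 (0.30 log units; within the scatter). Neither goes beyond the scatter, so no clear shift is expected in this assay. The expected result is a 1.3-fold lower number from compound 3 to compound 4 (0.12 log units; within the scatter), a step not beyond the scatter. For compound 4 the estimated value is 55000 nM, with an expected range of 28000 nM to 105000 nM.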

Compound 4, half-maximal inhibitory concentration: 41500 nM
For compound 4 the middle estimate is 1.3-fold (0.12 log units) above the measured one; low and high end bracket the measured number.
By their numbers in this assay, from the lowest: compounds 1, 4, 3 and 2 (each within the scatter of the next).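

In this assay, 2-acetoxyethyl in place of (2-hydroxyhexyl)carbonyl on an oxygen on a saturated carbon stays within the scatter (a 1.7-fold lower number from compound 3 to compound 4 (0.24 log units; within the scatter)), as does the same group in place of (furan-2-yl)carbonyl (a 1.9-fold lower number from compound 2 to compound 4 (0.29 log units; within the scatter)). Acetoxymethyl in place of 1-hydroxyethyl on a saturated chain carbon bound to an oxygen on a saturated carbon also stays within the scatter (a 1.0-fold higher number from compound 1 to compound 4 (0.01 log units; within the scatter)), so all four groups now shown on this oxygen, including 2-acetoxyethyl with its 0 hydrogen-bond donors, lie within the scatter of each other. Nothing at hand accounts for these steps.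

Still open, on these data alone, is whether a group of another kind on this oxygen, such as an amine or a carboxylic acid, would give a step beyond the scatter. The same holds for a much longer alkyl chain and for the free hydroxyl with no group on this oxygen.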